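Piperidinyl in Place of Aminopropyl on a Triazole

The source may report more compounds than this note shows. Statements on the series, on what has been measured and on what is new or still open speak of the compounds shown alone.

In an assay on cells for displacement of a labelled ligand from somatostatin receptor type 2 (Homo sapiens), with a stated time of 90 min (a higher number here means a weaker inhibitor, a lower number a stronger inhibitor), compound 3, `NCCCc1nnc(CCc2c[nH]c3ccccc23)n1Cc1ccccc1`, gives only a limit, > 10000 nM, and no number. Compound 1, `Clc1ccc(Cn2c(CCc3c[nH]cn3)nnc2Cc2c[nH]c3ccccc23)cc1Cl`, likewise stops at the limit of > 10000 nM in this assay. Compound 2, `c1ccc(Cn2c(Cc3c[nH]c4ccccc34)nnc2C2CCNCC2)cc1`, also reaches only the limit of > 10000 nM. All three recorded values therefore sit at the limit of > 10000 nM in this assay, at which 3 of the 3 values shown sit, so compound 3 cannot be placed above or below its neighbours; it simply shares the same limit.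

Compound 4, `c1ccc(Cn2c(CCc3c[nH]c4ccccc34)nnc2C2CCNCC2)cc1`, has not yet been measured in this assay. It differs from compound 3 in one place: piperidin-4-yl in place of 3-aminopropyl on an aromatic carbon. The benzyl group and the rest of the core are unchanged. For the measured compounds named here, no measured pair of compounds shows this exchange, so the recorded values give no size or direction for it. Compound 2 also carries a piperidin-4-yl group and gives only a limit, which offers no sign that this group brings a measurable number.

Compound 4 is therefore expected to give 10000 nM, with a range from 2500 nM to 40000 nM. The expected step of a number no higher from compound 3 to compound 4 (the limit leaves the size open) is none beyond the usual scatter, and the estimate most likely ends as another limit rather than a number.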

Compound 4, inhibition constant: > 10000 nM
Compound 4 ended at the assay's limit (the forecaster's own chance of this, stated with the estimate: 75%); the middle value sits exactly at the limit.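

Compound 3 and compound 4 both stop at a limit in this assay, so no step can be read for piperidin-4-yl in place of 3-aminopropyl on an aromatic carbon. The compounds shown leave open how large this exchange is, in either direction, and whether any of these structures gives a measurable number: the limit of > 10000 nM in this assay, at which 4 of the 4 values shown sit.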